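Methoxy on the pendant phenyl of compound 2

The source may report more compounds than this note shows. Statements on the series, on what has been measured and on what is new or still open speak of the compounds shown alone.

compound 1 `COc1ccc(-c2[nH]c3ccccc3c2/C=C(\C#N)S(=O)(=O)c2ccccc2)cc1`: 557 nM
compound 2 `COc1ccc2[nH]c(-c3ccccc3)c(C=C(C#N)C#N)c2c1`: 5400 nM

In a functional assay on PC-3 cells (Homo sapiens) for inhibition, read by sulforhodamine B assay, with a stated time of 48 h (on this read-out lower numbers stand for stronger inhibition of growth and higher numbers for weaker inhibition of growth), compound 2 gives the higher of the two numbers shown; compound 1 gives 557 nM but differs from compound 2 in more than one place, so no single step can be read between them. Compound 3 `COc1ccc(-c2[nH]c3ccc(OC)cc3c2C=C(C#N)C#N)cc1` carries methoxy in place of hydrogen on an aromatic carbon, the site being para to a large group. Within the data shown here, no measured pair isolates this change, so no step beyond the usual scatter is expected in this assay. For compound 3 the estimate is 3500 nM, with a range of 900 nM to 14000 nM, which means an expected step of a 1.5-fold lower number from compound 2 to compound 3 (0.19 log units; within the scatter).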

Compound 3, concentration for 50% growth inhibition: 342 nM
Compound 3: middle estimate off by 10-fold (1.01 log units), on the high side, outside the stated range (below it).
By their numbers in this assay, from the lowest: compounds 3 and 1 (each within the scatter of the next); then compound 2.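

In this assay the change from phenyl to 4-methoxyphenyl gives a 16-fold lower number from compound 2 to compound 3 (1.20 log units; beyond the scatter) and so shows that this aromatic carbon, para to a large group, is sensitive to substitution. Methoxy in place of hydrogen here is enough on its own to strengthen growth inhibition well beyond the scatter. Nothing on hand accounts for this gain.

Going by these compounds, whether the gain is specific to methoxy remains open, and hydroxy, fluorine or dimethylamino at this carbon would test that. On these data alone, whether ethoxy or a longer alkoxy chain is tolerated here also remains open.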